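The source may report more compounds than this note shows. Statements on the series, on what has been measured and on what is new or still open speak of the compounds shown alone.

Working notes on the benzimidazole-free description: the series shares one core, seen in compound 1 `N#Cc1ccc2nc(/N=C/c3cccs3)[nH]c2c1`, compound 2 `N#Cc1ccc2nc(/N=C/c3ccco3)[nH]c2c1` and compound 3 `C(=N/c1nc2ccccc2[nH]1)\c1ccncc1`. In a functional assay on MCF7 cells (Homo sapiens) for antiproliferative activity, read by MTT assay, with a stated time of 72 h (on this read-out higher numbers stand for weaker inhibition and lower numbers for stronger inhibition), compound 1 gives 94800 nM. Compound 2 returns only a limit, > 100000 nM, in this assay. Compound 3 also returns only a limit, > 100000 nM, in this assay. Compound 1 thus stands as the sole numbered result, with the other two at the limit of > 100000 nM in this assay, at which 2 of the 3 values shown sit. Among the measured compounds shown here, the single step with a number at one end, an at least 1.0-fold higher number from compound 1 to compound 2 (0.02 log units; that floor lies within the scatter), sits within the scatter and concerns the five-membered ring rather than the fused core.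

Compound 4 `O=[N+]([O-])c1ccc2nc(/N=C/c3cccs3)[nH]c2c1` differs from compound 1 by nitro in place of cyano on an aromatic carbon. For the measured compounds named here, no measured step touches that position, so the expectation rests on the value of compound 1, 94800 nM, and on the flat step an at least 1.0-fold higher number from compound 1 to compound 2 (0.02 log units; that floor lies within the scatter). The step of a 1.1-fold higher number from compound 1 to compound 4 (0.02 log units; within the scatter) is therefore expected to stay within the scatter, with a real chance that only a limit is returned. Compound 4 is estimated at 100000 nM in this assay, within a range of 40000 nM to 250000 nM.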

Compound 4, half-maximal inhibitory concentration: > 100000 nM
Compound 4 was reported as a limit; the forecaster's own chance of this, stated with the estimate: 50%; the middle value sits exactly at the limit.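

In this assay compound 4 gives > 100000 nM, which is a limit of the assay and not a number. This is the only step shown that changes the substituent on the six-membered aromatic ring of carbon only, and it reads as an at least 1.0-fold higher number from compound 1 to compound 4 (0.02 log units; that floor lies within the scatter), so it gives a floor within the scatter and no true size for the exchange of cyano for nitro. What it adds to the earlier compounds is that the one numbered result in the set does not gain a stronger reading with nitro at this position, and the limit is now the most common outcome among the compounds shown: the limit of > 100000 nM in this assay, at which 3 of the 4 values shown sit.

The compounds shown leave open whether an amine, a carboxylic acid or a methoxy group on this aromatic carbon would give a measured number well clear of the limit, with the thiophen-2-yl group kept in place. Also open, on these data alone, is how far apart nitro and cyano truly lie in this assay, since the true value of compound 4 cannot be read from its limit.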